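The source may hold more compounds than are shown below. What is called first, only, known or untested is meant among the compounds shown, and "the series" means these compounds.

Compound 1 `CCNc1nc(Cl)nc(N[C@H](C)c2ccccc2)n1` gives 2690 nM in an ADME assay on the whole organism for inhibition, with Echinochloa crus-galli var. formosensis as the target, with a stated time of 4 days; a higher number here means a weaker inhibitor, a lower number a stronger inhibitor.
Compound 2 `CCCCNc1nc(Cl)nc(N[C@H](C)c2ccccc2)n1` gives 38900 nM in this assay.
Compound 3 `CC[C@@H](C)Nc1nc(Cl)nc(N[C@H](C)c2ccccc2)n1` gives 4570 nM in this assay.

Among these three numbers compound 3 stands second highest. Its nearest neighbour is compound 1, and that gap, a 1.7-fold higher number from compound 1 to compound 3 (0.23 log units; within the scatter), lies within the scatter; its furthest is compound 2, from which the step of an 8.5-fold lower number from compound 2 to compound 3 (0.93 log units; beyond the scatter) runs beyond the scatter. Compound 4 `CC[C@H](C)Nc1nc(Cl)nc(N[C@H](C)c2ccccc2)n1` is the compound that follows. It differs from compound 3 in one respect: the two compounds have the same atoms and bonds and differ only in configuration as drawn: 1 of 2 stereo elements differ; a stereocentre at a saturated chain carbon is drawn R in compound 3 and S in compound 4. Going by the values given here, none of the measured steps alters configuration alone: a 14-fold higher number from compound 1 to compound 2 (1.16 log units; beyond the scatter) and a 1.7-fold higher number from compound 1 to compound 3 (0.23 log units; within the scatter) each add an ethyl to a chain carbon, and an 8.5-fold lower number from compound 2 to compound 3 (0.93 log units; beyond the scatter) exchanges butyl for sec-butyl on the ring nitrogen. Among the compounds with values here, no measured step therefore bears directly on this change, and the group on the ring nitrogen keeps the same atoms and bonds. Compound 4 is expected to land close to compound 3, with a step of a 1.1-fold higher number from compound 3 to compound 4 (0.04 log units; within the scatter) that is not expected to pass beyond the scatter. Compound 4 is estimated at 5000 nM in this assay, with an expected range from 1500 nM to 20000 nM.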

Compound 4, half-maximal inhibitory concentration: 52500 nM
For compound 4 the middle estimate is 11-fold (1.02 log units) below the measured one; the measured number lies above the stated range.
By their numbers in this assay, from the lowest: compounds 1 and 3 (each within the scatter of the next); then compounds 2 and 4 (each within the scatter of the next).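

Going by these compounds alone, the stereocentre at this saturated chain carbon carries a large step in this assay that the earlier compounds could not reveal, an 11-fold higher number from compound 3 to compound 4 (1.06 log units; beyond the scatter), because nothing else separates the pair: the fact that compounds 3 and 4 differ only in the configuration as drawn. Sec-butyl in place of butyl therefore has no single outcome, since the form drawn S gives a 1.3-fold higher number from compound 2 to compound 4 (0.13 log units; within the scatter), while the form drawn R gave an 8.5-fold lower number from compound 2 to compound 3 (0.93 log units; beyond the scatter). Likewise, ethyl in place of hydrogen on this carbon gives a 20-fold higher number from compound 1 to compound 4 (1.29 log units; beyond the scatter) in the S form, against a 1.7-fold higher number from compound 1 to compound 3 (0.23 log units; within the scatter) in the R form.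

The compounds shown leave open whether configuration counts as much in another branched group on the ring nitrogen, such as 1-methylbutyl. They also leave open what inverting the second stereocentre, drawn alike in all four compounds, would do.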